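This account rests on a few compounds, and the source may have more. Where it says the series, first, only, none or still open, it means among the compounds named here.

In a functional assay on MV4-11 cells (Homo sapiens) for antiproliferative activity, read by CellTiter-Glo, with a stated time of 72 h (a lower number here means a stronger inhibitor of growth, a higher number a weaker inhibitor of growth), compound 1 `N[C@H]1CC[C@H](Nc2cc(-c3csc(NCC4CCOCC4)n3)c(Cl)cn2)CC1` gives 140 nM and compound 2 `COCCN[C@H]1CC[C@H](Nc2cc(-c3csc(NCC4CCOCC4)n3)c(C)cn2)CC1` gives 1620 nM while compound 3 `COCCN[C@H]1CC[C@H](Nc2cc(-c3csc(OCC4CCOCC4)n3)c(Cl)cn2)CC1` gives 570 nM as the middle number of the three. Compound 3 therefore stands above compound 1 and below compound 2 on the numbers, with both gaps beyond the scatter. No two of these compounds differ in one place only, so no single change can be sized from them.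

Compound 4 `COCCN[C@H]1CC[C@H](Nc2cc(-c3csc(NCC4CCCC4)n3)c(Cl)cn2)CC1` carries (cyclopentylmethyl)amino in place of the (oxan-4-yl)methoxy of compound 3 on an aromatic carbon (cyclopentylmethyl)amino in place of (oxan-4-yl)methoxy on an aromatic carbon and is otherwise unchanged. Compound 1 and compound 2 also have an amino link at this place, but they fall on opposite sides of compound 3, so the link alone sets no direction. Going by the values given here, no measured compound shows the carbon-only five-membered ring. The amino link and the chlorine of compound 4 occur together in one measured compound only, compound 1, which gives 140 nM and this tilts the expectation slightly towards a lower number. A small step towards stronger growth inhibition is expected, with a 1.9-fold lower number from compound 3 to compound 4 (0.28 log units; within the scatter) as the estimate. For compound 4 the estimated value is 300 nM with an expected range from 80 nM to 1000 nM in this assay.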

Compound 4, concentration for 50% growth inhibition: 2160 nM
The estimate for compound 4 lay 7.2-fold (0.86 log units) below the measured number; measured number outside the range, above it.
By their numbers in this assay, from the lowest: compound 1; then compound 3; then compounds 2 and 4 (each within the scatter of the next).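

In this assay, going by these compounds alone, (cyclopentylmethyl)amino in place of (oxan-4-yl)methoxy on an aromatic carbon of the five-membered aromatic ring with 1 nitrogen and 1 sulfur gives a 3.8-fold higher number from compound 3 to compound 4 (0.58 log units; beyond the scatter) and is the first step at this position that can be sized, showing that growth inhibition responds to the group carried here. The change is a double one, with an amino link replacing an oxygen link and a five-membered non-aromatic ring of carbon only replacing a six-membered non-aromatic ring with 1 hetero atom, and this single step cannot divide its size between the two. Nothing available on this pair explains the step.

From the compounds shown here alone, how much of the step belongs to the link and how much to the ring stays open, and cyclopentylmethoxy or (oxan-4-yl)methylamino on the core of compound 3 would separate the two. Also open, going by these compounds, is how this position responds to groups of other kinds, such as a plain amine, a carboxylic acid or a longer open carbon chain.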